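A few compounds are considered here, and "the series" means these few. Any claim that something is new, unique, unknown or untested is made for them only; others in the source may bear on it.

Series notes. Three compounds share a benzimidazolyl-terphenyl arrangement and differ at two ends. Compound 1 `Oc1cccc2[nH]c(-c3ccc(-c4ccc(-c5ccc(C(F)(F)F)cc5)cc4)cc3)nc12` is the reference; in a functional assay on MCF7 cells (Homo sapiens) for inhibition, read by sulforhodamine B assay (on this read-out lower numbers stand for stronger inhibition of growth and higher numbers for weaker inhibition of growth), compound 1 gives 2310 nM. Compound 2 `Oc1cccc2[nH]c(-c3ccc(-c4ccc(-c5ccc(OC(F)(F)F)cc5)cc4)cc3)nc12` carries the change (trifluoromethoxy in place of trifluoromethyl on an aromatic carbon); in this assay compound 2 gives 2210 nM, and the step of a 1.0-fold lower number from compound 1 to compound 2 (0.02 log units; within the scatter) is within the scatter, so the two values are not told apart. Compound 3 `Cc1ccc2[nH]c(-c3ccc(-c4ccc(-c5ccc(C(F)(F)F)cc5)cc4)cc3)nc2c1` differs from compound 1 in the core, as counted in 5-methyl-1H-benzimidazol-2-yl in place of 4-hydroxy-1H-benzimidazol-2-yl on an aromatic carbon; in this assay compound 3 gives 31000 nM, a large step of a 13-fold higher number from compound 1 to compound 3 (1.13 log units; beyond the scatter).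

Compound 4 `Cc1ccc2[nH]c(-c3ccc(-c4ccc(-c5ccc(OC(F)(F)F)cc5)cc4)cc3)nc2c1` is not yet measured. It stands to compound 3 as compound 2 stands to compound 1: the change (trifluoromethoxy in place of trifluoromethyl on an aromatic carbon), at a place described in the same words in both pairs, so it is the same change on a different core. Among the compounds with values here, the only measured instance of this change gave the flat step from compound 1 to compound 2; on that basis the step from compound 3 to compound 4 is expected to be equally flat, no change at the digits printed from compound 3 to compound 4 (within the scatter), with no reason from the data to expect otherwise. Compound 4 is therefore estimated at 31000 nM, with a range of 12000 nM to 80000 nM in this assay.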

Compound 4, concentration for 50% growth inhibition: 31000 nM
The estimate for compound 4 equals the measured number at the digits printed; low and high end bracket the measured number.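

In this assay the exchange of trifluoromethyl for trifluoromethoxy stays flat on the second core, no change at the digits printed from compound 3 to compound 4 (within the scatter), and the two instances agree: the same change on two cores in this assay, a 1.0-fold lower number (0.02 log units; within the scatter) from compound 1 to compound 2 and no change at the digits printed (within the scatter) from compound 3 to compound 4, 1.0-fold (0.02 log units) apart, within the scatter of two such steps

The core change likewise keeps its size with trifluoromethoxy in place, a 14-fold higher number from compound 2 to compound 4 (1.15 log units; beyond the scatter), and the two core steps agree: the same change on two cores in this assay, a 13-fold higher number (1.13 log units; beyond the scatter) from compound 1 to compound 3 and a 14-fold higher number (1.15 log units; beyond the scatter) from compound 2 to compound 4, 1.0-fold (0.02 log units) apart, within the scatter of two such steps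

This shows that, across these four compounds, the two changes can be read separately, but it rests on two cores and a single pair of groups, and a flat step carrying over does not show that a change with a large effect at this end would carry over as well; the core step also swaps hydroxy and methyl in one move, so it does not separate the two.

Open, from the compounds shown here alone, is whether an amine or a carboxylic acid in the place of trifluoromethyl would move the number, and whether such a step would hold on both cores. Also open, going by these compounds, is where a core carrying neither hydroxy nor methyl would stand.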